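Shortening the carbamate chain in a selenocyanate series

The source may hold more compounds than are shown below. What is called first, only, known or untested is meant among the compounds shown, and "the series" means these compounds.

Compound 1, `CCCOC(=O)Nc1ccc([Se]C#N)cc1`, compound 2, `CC(C)COC(=O)Nc1ccc([Se]C#N)cc1`, and compound 3, `CCCCCCOC(=O)Nc1ccc([Se]C#N)cc1`, share one core and differ only in the carbamate chain. In a functional assay on PC-3 cells (Homo sapiens) for cytotoxicity, read by MTT assay, with a stated time of 72 h (a higher number here means a weaker inhibitor of growth, a lower number a stronger inhibitor of growth), compound 1 gives 47400 nM, compound 2 gives 47300 nM, and compound 3 gives 44600 nM, the lowest number of the three, though the step of a 1.1-fold lower number from compound 1 to compound 3 (0.03 log units; within the scatter) and the step of a 1.1-fold lower number from compound 2 to compound 3 (0.03 log units; within the scatter) are both within the scatter, as is a 1.0-fold lower number from compound 1 to compound 2 (0.00 log units; within the scatter). Compound 4, `CCOC(=O)Nc1ccc([Se]C#N)cc1`, differs from compound 3 by hydrogen in place of butyl on a saturated chain carbon, two bonds along the chain from an oxygen next to a carbonyl group. The steps from compound 1 and from compound 2 to compound 3 bear on this change and were within the scatter, so no step beyond the scatter is expected in this assay. Compound 4 is therefore expected to give 46000 nM, in a range from 25000 nM to 85000 nM, an expected step of a 1.0-fold higher number from compound 3 to compound 4 (0.01 log units; within the scatter).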

Compound 4, concentration for total growth inhibition: 39200 nM
Beside the measured number, compound 4's estimate is 1.2-fold (0.07 log units) above it; the range from low to high includes it.
By their numbers in this assay, from the lowest: compounds 4, 3, 2 and 1 (each within the scatter of the next).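

In this assay, cutting the chain from hexyl to ethyl gives a 1.1-fold lower number from compound 3 to compound 4 (0.06 log units; within the scatter), so even this large change in chain length does not separate the two compounds. The branched chain and the propyl chain behave alike, with a 1.2-fold lower number from compound 2 to compound 4 (0.08 log units; within the scatter) and a 1.2-fold lower number from compound 1 to compound 4 (0.08 log units; within the scatter). Compound 4 thus extends the set of chains at this position without any step beyond the scatter.

As far as these compounds go, whether a chain longer than hexyl, or an amine or a phenyl ring on the chain, would move the number remains open. No measurement at hand accounts for this flat response.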